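The source may report more compounds than this note shows. Statements on the series, on what has been measured and on what is new or still open speak of the compounds shown alone.

Compound 2 `Cc1c(Cc2ccccc2)c(=O)oc2cc(OCC(O)CNCC3CC3)ccc12` carries a (cyclopropylmethyl)amino group on the shared core. In an ADME assay on A549 cells (Homo sapiens) for cytotoxicity, read by CellTiter-Glo (on this read-out higher numbers stand for lower toxicity in this test and lower numbers for higher toxicity in this test), compound 2 is reported only as > 100000 nM, a limit of the assay rather than a number. Its neighbour compound 1 `C#CCNCC(O)COc1ccc2c(C)c(Cc3ccccc3)c(=O)oc2c1` differs in that ethynyl stands in place of cyclopropyl on the saturated chain carbon bound to the amine nitrogen; in this assay compound 1 gives 95500 nM. The step of an at least 1.0-fold higher number from compound 1 to compound 2 (0.01 log units; that floor lies within the scatter) is the only measured one in the set, and the limit of > 100000 nM in this assay, at which 1 of the 2 values shown sits, is where compound 2 sits. Compound 3 `Cc1c(Cc2ccccc2)c(=O)oc2cc(OCC(O)CNc3ccccc3)ccc12` is not yet measured; it differs from compound 2 by phenyl in place of cyclopropylmethyl on an amine nitrogen. Among the measured compounds shown here, no measured step covers an aromatic ring on this nitrogen, so the expectation rests on the single step from compound 1 to compound 2 remaining within the scatter. Compound 3 is therefore expected to show a step of an at least 1.1-fold lower number from compound 2 to compound 3 (0.07 log units; that floor lies within the scatter). The estimate for compound 3 is 85000 nM, between 35000 nM and 100000 nM.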

Compound 3, half-maximal cytotoxic concentration: > 100000 nM
Compound 3 was reported as a limit; the forecaster's own chance of this, stated with the estimate: 45%; middle value at least 1.1-fold (0.07 log units) away from the limit.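

An aromatic ring now stands on the amine nitrogen, and in this assay compound 3 is reported as a limit of the assay, as compound 2 is: the limit of > 100000 nM in this assay, at which 2 of the 3 values shown sit. The step between these two limits cannot be read. Phenyl in place of propargyl on the amine nitrogen gives an at least 1.0-fold higher number from compound 1 to compound 3 (0.01 log units; that floor lies within the scatter), so the aromatic ring on this nitrogen brings no drop in the number beyond the scatter.

Compound 1 remains the only compound read as a number, and none of the groups shown on this nitrogen sets a clear difference in this assay. On these data alone, whether a benzyl group, a second alkyl group on the same nitrogen or a carboxylic acid on the chain would give a value inside the range of the assay stays open.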